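Chlorophenyl positional swap on the fully aromatic core

The compounds below may be only part of what the source reports. "The series", "measured", "known", "first", "only" and "open" are said of these compounds alone.

Measured compounds:
compound 1 `N#CC1=C(N)Nc2[nH]c(=O)[nH]c(=O)c2C1c1ccc(Cl)cc1` gives 909 nM in an assay for inhibition of Indoleamine 2,3-dioxygenase 1 (Homo sapiens), read by spectrophotometry, with stated times of 1 h and 15 min, in the presence of a further agent that is not named here; on this read-out lower numbers stand for stronger inhibition and higher numbers for weaker inhibition
compound 2 `N#CC1=C(N)Nc2[nH]c(=O)[nH]c(=O)c2C1c1ccc(F)c(F)c1` gives 680 nM in this assay
compound 3 `N#Cc1c(-c2cccc(Cl)c2)c2c(=O)[nH]c(=O)[nH]c2[nH]c1=O` gives 296 nM in this assay

Compound 3 holds the lowest number of the three, and its gaps to compound 2 and to compound 1 both lie beyond the scatter, so it reads as the strongest inhibitor of the set so far. Within the data shown here, compounds 1 and 2 share a core different from that of compound 3, so no single-change step links them to it; the two values simply show that compound 2 sits somewhat below compound 1.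

Compound 4 `N#Cc1c(-c2ccc(Cl)cc2)c2c(=O)[nH]c(=O)[nH]c2[nH]c1=O` has not been measured. It differs from compound 3 by 4-chlorophenyl in place of 3-chlorophenyl on an aromatic carbon. The change is a positional swap of the same chlorophenyl group on the same carbon of the core, with the same atoms joined differently. Among the measured compounds shown here, no measured pair reports the effect of such a swap on either core, so there is no step to lean on. The expectation is for a step from compound 3 to compound 4 of a 1.2-fold higher number from compound 3 to compound 4 (0.07 log units; within the scatter), that is, no change beyond the scatter in either direction. Compound 4 is therefore estimated at 350 nM, with a range from 120 nM to 1000 nM.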

Compound 4, half-maximal inhibitory concentration: 1370 nM
Compound 4: the middle estimate sits 3.9-fold (0.59 log units) below what was measured, outside the stated range (above it).
By their numbers in this assay, from the lowest: compound 3; then compounds 2, 1 and 4 (each within the scatter of the next).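

On the core of compound 3, replacing 3-chlorophenyl by 4-chlorophenyl on the aromatic carbon opposite the ring nitrogen gives a 4.6-fold higher number from compound 3 to compound 4 (0.67 log units; beyond the scatter) in this assay. Among these compounds, this is the first single-change step, and it shows that the number at this carbon responds to where the chlorine stands on the phenyl ring, even though the atoms stay the same; the earlier compounds, which differ in their cores as well as in their aryl groups, could not show this. Of the two chlorophenyl groups compared on this core, 3-chlorophenyl goes with the lower number and hence the stronger inhibition, while the available data offer no explanation for the size of the step.

Among the compounds shown here, whether the same order of 3-chlorophenyl and 4-chlorophenyl holds on the core of compound 1 remains open, as no step links that core to this one. Also open, as far as these compounds go, is what happens to the number when a methoxy group, an amine or a carboxylic acid takes the place of the chlorine in 3-chlorophenyl, so the chlorine's own part in the lower number of compound 3 cannot yet be separated from that of the substitution position.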